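Swapping the sulfur-linked heterocycle in an imidazole amide series

The source may report more compounds than this note shows. Statements on the series, on what has been measured and on what is new or still open speak of the compounds shown alone.

The measured compounds and their results in a functional assay on HT-29 cells (Homo sapiens) for cytotoxicity, read by MTT assay, with a stated time of 24 h; on this read-out lower numbers stand for stronger inhibition and higher numbers for weaker inhibition:
Compound 1, `Cn1c(-c2ccc(NC(=O)CSc3nc4ccccc4o3)cc2)nc(-c2ccccc2)c1-c1ccccc1`, gives 11 ug/mL.
Compound 2, `Cn1c(-c2ccc(NC(=O)CSc3nc4ccccc4s3)cc2)nc(-c2ccccc2)c1-c1ccccc1`, gives 18 ug/mL.
Compound 3, `Cn1c(-c2ccc(NC(=O)CSC3=NCCS3)cc2)nc(-c2ccccc2)c1-c1ccccc1`, gives 21 ug/mL.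

All three share the same core and differ only in the ring attached to the sulfur. The steps of a 1.6-fold higher number from compound 1 to compound 2 (0.21 log units; within the scatter), a 1.9-fold higher number from compound 1 to compound 3 (0.28 log units; within the scatter) and a 1.2-fold higher number from compound 2 to compound 3 (0.07 log units; within the scatter) all lie within the scatter, so compound 3 cannot be told apart from the other two on these numbers.

Compound 4, `Cn1ccnc1SCC(=O)Nc1ccc(-c2nc(-c3ccccc3)c(-c3ccccc3)n2C)cc1`, makes a further change at the same place: a group of 6 heavy atoms (4 carbon, 2 nitrogen; one five-membered aromatic ring with 2 hetero atoms) in place of a group of 5 heavy atoms (3 carbon, 1 nitrogen, 1 sulfur; one five-membered non-aromatic ring with 2 hetero atoms), on a sulfur. The two steps that bear on it are the ones where the ring on the sulfur was exchanged, a 1.9-fold higher number from compound 1 to compound 3 (0.28 log units; within the scatter) and a 1.2-fold higher number from compound 2 to compound 3 (0.07 log units; within the scatter), and neither left the scatter. A step of the same kind is therefore expected to stay within the scatter, with no direction to prefer.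

Compound 4 is estimated at 18 ug/mL, with a range from 8 ug/mL to 40 ug/mL, which means an expected step of a 1.2-fold lower number from compound 3 to compound 4 (0.07 log units; within the scatter).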

Compound 4, half-maximal inhibitory concentration: 47.5 ug/mL
Beside the measured number, compound 4's estimate is 2.6-fold (0.42 log units) below it, and the stated range ends below it.
By their numbers in this assay, from the lowest: compounds 1, 2 and 3 (each within the scatter of the next); then compound 4.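

For the compounds shown here, the ring on the sulfur is less forgiving than the earlier compounds suggested: 1-methyl-1H-imidazol-2-yl gives a 2.3-fold higher number from compound 3 to compound 4 (0.35 log units; beyond the scatter) and a 2.6-fold higher number from compound 2 to compound 4 (0.42 log units; beyond the scatter) and a 4.3-fold higher number from compound 1 to compound 4 (0.64 log units; beyond the scatter) in this assay, the first steps at this position to lie beyond the scatter. All three are modest and point the same way, so this change separates compound 4 from three compounds that cannot be told apart from one another. No measurement here accounts for the higher number of compound 4.

The compounds shown leave open whether the higher number goes with the imidazole ring or with its methyl group, a question that a 1H-imidazol-2-yl group would address. They also leave open how an open chain on the sulfur, such as an ethyl group, would compare with these rings.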